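Adding a methoxy to a compound at the assay limit

The source may report more compounds than this note shows. Statements on the series, on what has been measured and on what is new or still open speak of the compounds shown alone.

Compound 3 (`c1ccc(Cn2ccc3nc(-c4ccccc4)nc-3c2)cc1`) has no exact number in an ADME assay on MDBK cells (Bos taurus) for cytotoxicity; a higher number here means that more compound is tolerated, a lower number that less compound is tolerated: its result is only the limit > 100000 nM. Compound 1 (`Fc1cccc(F)c1Cn1ccc2nc(-c3c(F)cccc3F)nc-2c1`) also gives only a limit, > 100000 nM. Compound 2 (`Fc1cccc(F)c1-c1nc2ccn(Cc3ccccc3)cc-2n1`) likewise gives only a limit, > 100000 nM. The measured set therefore comes down to the limit of > 100000 nM in this assay, at which 3 of the 3 values shown sit.

Compound 4 (`COc1ccccc1Cn1ccc2nc(-c3ccccc3)nc-2c1`) is compound 3 with methoxy in place of hydrogen on an aromatic carbon, ortho to a large group: methoxy in place of hydrogen on an aromatic carbon. In other words, a phenyl becomes a 2-methoxyphenyl.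

For the measured compounds named here, two measured steps bear on this only indirectly. Going by the values given here, the first is a step that the two limits leave unreadable from compound 1 to compound 2. The second is a step that the two limits leave unreadable from compound 2 to compound 3. Both exchange 2,6-difluorophenyl for phenyl, neither adds a methoxy, and neither has a readable size, since limits stand at both ends. Among the compounds with values here, they show only that all three compounds reach the same limit, whichever of these groups they carry. No step beyond the scatter is therefore expected, in either direction, though this rests on thin evidence. The expected change is a number no higher from compound 3 to compound 4 (the limit leaves the size open). Compound 4 is estimated at 100000 nM, within an expected range of 50000 nM to 200000 nM.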

Compound 4, half-maximal cytotoxic concentration: > 100000 nM
Compound 4: no number, only a limit (the forecaster's own chance of this, stated with the estimate: 85%); the middle value lies on the limit itself.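

For the compounds shown here, compound 3 and compound 4 each give only a limit in this assay, so no step between them can be read, and the same holds for the whole set: the limit of > 100000 nM in this assay, at which 4 of the 4 values shown sit. The compounds shown leave open where the true cytotoxic concentration of each compound lies, and whether adding the methoxy changes it at all.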